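This account rests on a few compounds, and the source may have more. Where it says the series, first, only, none or still open, it means among the compounds named here.

Working notes on the series in a functional assay on PC-3 cells (Homo sapiens) for inhibition, read by MTT assay, with a stated time of 48 h, tested at 10 uM; on this read-out higher numbers stand for more inhibition of growth at the one concentration tested and lower numbers for less inhibition of growth. Compound 1 `Cc1oc2c([C@H]3CCN(C)C[C@H]3O)c(O)cc(O)c2c(=O)c1C(O)c1ccc([N+](=O)[O-])cc1` gives 24%. Among the compounds with values here, compound 2 `Cc1oc2c([C@H]3CCN(C)C[C@H]3O)c(O)cc(O)c2c(=O)c1C(O)c1c(Cl)cccc1Cl` gives 0%, the lower of the two numbers so far. The next analogue is compound 3 `CCOc1ccc(Br)c(C(O)c2c(C)oc3c([C@H]4CCN(C)C[C@H]4O)c(O)cc(O)c3c2=O)c1`, and the change is 2-bromo-5-ethoxyphenyl in place of 2,6-dichlorophenyl on a saturated chain carbon bound to an aromatic carbon and an oxygen on a saturated carbon. Within the data shown here, one measured step bears on this place: a number 24 percentage points lower from compound 1 to compound 2 (beyond the scatter). It shows that exchanging the group on this carbon can move the read-out beyond the scatter, but a single pair gives no rule for the new group. Among the measured compounds shown here, with compound 2 at 0%, a modest upward move is expected, no larger than that step. The expected change is a number 10 percentage points higher from compound 2 to compound 3 (within the scatter). For compound 3 the estimated value is 10%, with an expected range of 0% to 28%.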

Compound 3, percent growth inhibition at one concentration: 0%
Compound 3: the middle estimate sits 10 percentage points above what was measured; low and high end bracket the measured number.
By their numbers in this assay, from the lowest: compounds 2 and 3 (each within the scatter of the next); then compound 1.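

In this assay, replacing one halogen-bearing aryl group with another at this carbon gives no change at the digits printed from compound 2 to compound 3 (within the scatter), so 2-bromo-5-ethoxyphenyl and 2,6-dichlorophenyl cannot be told apart here, even though the entering group adds an ethoxy chain and a hydrogen-bond acceptor. Within the data shown here, the second comparison gives a number 24 percentage points lower from compound 1 to compound 3 (beyond the scatter), which means the gap first seen for compound 2 recurs with a differently substituted ring, and 4-nitrophenyl remains the only group at this carbon that stands clear of the others. No available measurement accounts for this separation.

Going by these compounds, it remains open whether the nitro group itself matters or whether the halogens matter instead, and an unsubstituted phenyl or an aminophenyl on the same carbon would bear on that. How a carboxylic acid or a saturated ring such as cyclohexyl would read at this carbon is also unresolved.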